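The source may hold more compounds than are shown below. What is called first, only, known or untested is meant among the compounds shown, and "the series" means these compounds.

Measured so far:
- compound 1 `COc1ccc(/C=N/NC(=O)CSc2nnc(-c3ccncc3)n2-c2ccccc2)cc1`: 23700 nM in a functional assay on MCF7 cells (Homo sapiens) for inhibition, read by MTT assay, with a stated time of 48 h; a higher number here means a weaker inhibitor, a lower number a stronger inhibitor
- compound 2 `O=C(CSc1nnc(-c2ccncc2)n1-c1ccccc1)N/N=C/c1ccc(O)c(O)c1`: 19700 nM

Among the measured compounds shown here, compound 2 has the lowest number of the two, but its only neighbour, compound 1, sits within the scatter of it, as the step of a 1.2-fold lower number from compound 1 to compound 2 (0.08 log units; within the scatter) shows. Compound 3 `O=C(CSc1nnc(-c2ccncc2)n1-c1ccccc1)N/N=C/C=C/c1ccccc1` differs from compound 2 by 2-phenylethenyl in place of 3,4-dihydroxyphenyl on a carbon with a double bond to nitrogen. For the measured compounds named here, the one measured step at that place, a 1.2-fold lower number from compound 1 to compound 2 (0.08 log units; within the scatter), also an aryl-for-aryl exchange on a carbon with a double bond to nitrogen, stayed within the scatter, so no step beyond the scatter is expected in this assay for compound 3. Compound 3 is estimated at 20000 nM, range 7000 nM to 55000 nM, an expected step of a 1.0-fold higher number from compound 2 to compound 3 (0.01 log units; within the scatter).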

Compound 3, half-maximal inhibitory concentration: 11200 nM
Compound 3: the middle estimate sits 1.8-fold (0.25 log units) above what was measured; the measured number falls inside the stated range.
By their numbers in this assay, from the lowest: compounds 3, 2 and 1 (each within the scatter of the next, the first and the last beyond it).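

In this assay, among the compounds shown here, 2-phenylethenyl on the carbon with a double bond to nitrogen gives the first step beyond the scatter, though a modest one (a 2.1-fold lower number from compound 1 to compound 3 (0.33 log units; beyond the scatter)), when it replaces 4-methoxyphenyl. Replacing 3,4-dihydroxyphenyl stays within the scatter (a 1.8-fold lower number from compound 2 to compound 3 (0.25 log units; within the scatter)), so this place accepts a group with 0 hydrogen-bond donors and 0 hydrogen-bond acceptors as well as one with 2 of each. No data bearing on a cause for these steps are at hand.
Still open, as far as these compounds go, is how an amine, a carboxylic acid or a longer chain ending in phenyl would read at this place.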